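This account rests on a few compounds, and the source may have more. Where it says the series, first, only, none or still open, it means among the compounds named here.

Measured compounds:
Compound 1 `Nc1ccc(-c2cnc(C(=O)CCCCCCc3ccccc3)o2)cc1`, in an assay (Rattus norvegicus) for inhibition of Fatty-acid amide hydrolase 1 (Homo sapiens) (on this read-out lower numbers stand for stronger inhibition and higher numbers for weaker inhibition), compound 1 gives 90 nM.
Compound 2 `COC(=O)c1ccc(-c2cnc(C(=O)CCCCCCc3ccccc3)o2)cc1`, compound 2 gives 40 nM.
Compound 3 `O=C(CCCCCCc1ccccc1)c1ncc(-c2ccc(O)cc2)o1`, compound 3 gives 140 nM.

Compound 3 holds the highest of the three numbers; against compound 1 the difference is within the scatter a 1.6-fold higher number from compound 1 to compound 3 (0.19 log units; within the scatter), against compound 2 it is beyond it a 3.5-fold higher number from compound 2 to compound 3 (0.54 log units; beyond the scatter). Compound 4 `O=C(CCCCCCc1ccccc1)c1ncc(-c2ccc(C(=O)C(F)(F)F)cc2)o1` differs from compound 3 by (trifluoromethyl)carbonyl in place of hydroxy on an aromatic carbon. The step from compound 2 to compound 3 bears most on this change, since it replaced a carbonyl-bearing group on the same aromatic carbon with hydroxy and gave a higher number; the step from compound 1 to compound 3 stayed within the scatter. A modest lowering of the number is therefore expected for compound 4, a 4.0-fold lower number from compound 3 to compound 4 (0.60 log units; beyond the scatter). Compound 4 is estimated at 35 nM, in a range from 12 nM to 100 nM.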

Compound 4, inhibition constant: 65 nM
Beside the measured number, compound 4's estimate is 1.9-fold (0.27 log units) below it; measured number inside the range.
By their numbers in this assay, from the lowest: compounds 2, 4, 1 and 3 (each within the scatter of the next, the first and the last beyond it).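

In this assay the (trifluoromethyl)carbonyl group on this aromatic carbon, para to a large group, gives a 2.2-fold lower number from compound 3 to compound 4 (0.33 log units; beyond the scatter) and so joins the methoxycarbonyl of compound 2 as a carbonyl-bearing group with a lower number than hydroxy. Trifluoromethyl in place of methoxy on the carbonyl carbon gives a 1.6-fold higher number from compound 2 to compound 4 (0.21 log units; within the scatter) and the change from amino gives a 1.4-fold lower number from compound 1 to compound 4 (0.14 log units; within the scatter) and so neither exchange separates the pair. Nothing available explains these differences.

On these data alone, whether a carboxylic acid or a nitrile on this aromatic carbon would keep such numbers remains open.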